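A few compounds are considered here, and "the series" means these few. Any claim that something is new, unique, unknown or untested is made for them only; others in the source may bear on it.

In an ADME assay on a cell-free system (plasma, Homo sapiens) (a lower number here means a smaller unbound share, a higher number a larger unbound share of the compound), compound 1 `CN(C)S(=O)(=O)c1ccc(F)c(C#Cc2cc(Cl)ccc2OCC(=O)O)c1` gives 0.009, compound 2 `CCCS(=O)(=O)c1ccc(F)c(C#Cc2cc(Cl)ccc2OCC(=O)O)c1` gives 0.01, and compound 3 `Cc1ccc(S(=O)(=O)NC(C)C)cc1C#Cc1cc(Cl)ccc1OCC(=O)O` gives 0.004, the lowest of the three. Compound 4 `Cc1ccc(S(C)(=O)=O)cc1C#Cc1cc(Cl)ccc1OCC(=O)O` departs from compound 3 by one change (methyl in place of isopropylamino on a sulfonyl sulfur), with methyl in place of isopropylamino on a sulfonyl sulfur. Within the data shown here, the only measured step at such a sulfur, a 1.1-fold higher number from compound 1 to compound 2 (0.05 log units; within the scatter), puts propyl in place of dimethylamino and stays within the scatter. That swap is a different one, so it is only a loose guide. It points to a small change, and a slight upward drift from the lowest value seems likely. The expected move is a 1.8-fold higher number from compound 3 to compound 4 (0.24 log units; within the scatter). For compound 4 the estimated value is 0.007, with an expected range from 0.004 to 0.014.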

Compound 4, unbound fraction: 0.017
Compound 4: the middle estimate sits 2.4-fold (0.39 log units) below what was measured; the whole stated range lies below it.
By their numbers in this assay, from the lowest: compound 3; then compounds 1, 2 and 4 (each within the scatter of the next).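

In this assay, putting methyl in place of isopropylamino on the sulfonyl sulfur gives a 4.3-fold higher number from compound 3 to compound 4 (0.63 log units; beyond the scatter). A swap at this sulfur can therefore move the unbound share beyond the scatter, which the earlier step, a 1.1-fold higher number from compound 1 to compound 2 (0.05 log units; within the scatter), did not show. Nothing measured here accounts for the rise. This one step removes the nitrogen and the carbons of isopropylamino together, so it cannot say which of them matters. Going by these compounds, how an ethyl group or a plain amino group on the same sulfur would behave remains open.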